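The source may report more compounds than this note shows. Statements on the series, on what has been measured and on what is new or still open speak of the compounds shown alone.

Measured so far:
- compound 1, `COc1cc(OC)c(OC)cc1/C=C/C(=O)c1ccc(C)cc1`: 42200 nM
- compound 2, `COc1cc(OC)c(OC)cc1/C=C/C(=O)c1ccc(Cl)c([N+](=O)[O-])c1`: 16500 nM

Both compounds were tested in a functional assay on HeLa cells (Homo sapiens) for inhibition, read by MTT assay, with a stated time of 72 h; on this read-out higher numbers stand for weaker inhibition and lower numbers for stronger inhibition. Of the two numbers, compound 1 gives the higher one, so on this read-out it is the weaker inhibitor; compound 2 gives the lower number, and the gap between the two is wider than the usual scatter of repeated measurements.

The next compound, compound 3, `COc1cc(OC)c(OC)cc1/C=C/C(=O)c1ccc(Br)cc1`, differs from compound 1 in one place only: bromo in place of methyl on an aromatic carbon. Among the compounds with values here, nothing measured so far shows a step of exactly this kind, so no size can be read off from the data, and only an expectation can be given. A modest change is expected, if any, with the direction uncertain; the step of a 1.4-fold lower number from compound 1 to compound 3 (0.15 log units; within the scatter) is estimated to stay close to the scatter. Compound 3 is therefore expected to give about 30000 nM, within a range from 8000 nM to 100000 nM.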

Compound 3, half-maximal inhibitory concentration: 31700 nM
The estimate for compound 3 lay 1.1-fold (0.02 log units) below the measured number; low and high end bracket the measured number.
By their numbers in this assay, from the lowest: compounds 2, 3 and 1 (each within the scatter of the next, the first and the last beyond it).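

In this assay, bromo in place of methyl on this aromatic carbon, para to a large group, gives a 1.3-fold lower number from compound 1 to compound 3 (0.12 log units; within the scatter) and so stays within the scatter. Within the data shown here, this is the first step that changes one place only, and it shows that the 4-methylphenyl and 4-bromophenyl forms of the shared core cannot be told apart on this read-out. There is no measured information here that could explain this result.

On these data alone, it remains open whether a group of a different kind at this position, such as an amine, a carboxylic acid or a longer chain, would shift the number beyond the scatter. As far as these compounds go, it also remains open whether the same exchange of methyl for bromo would give a similarly small step at another position on this ring.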